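The compounds below may be only part of what the source reports. "The series", "measured", "known", "first", "only" and "open" are said of these compounds alone.

Measured in a functional assay on K562 cells (Homo sapiens) for cytotoxicity, read by trypan blue exclusion, with a stated time of 96 h; a lower number here means a stronger inhibitor, a higher number a weaker inhibitor:
- compound 1 `COc1cc(OC)c(/C=C/S(=O)(=O)Nc2ccc(F)c(N)c2)c(OC)c1` gives 5000 nM
- compound 2 `COc1cc(OC)c(/C=C/S(=O)(=O)Nc2cc(N)c(OC)c(N)c2)c(OC)c1` gives 7500 nM
- compound 3 `COc1cc(OC)c(/C=C/S(=O)(=O)Nc2ccc(OC)c(N)c2)c(OC)c1` gives 3 nM

Compound 3 has the lowest number of the three, and its gaps to both others lie beyond the scatter. Compound 4 `COC(=O)C(Nc1cc(NS(=O)(=O)/C=C/c2c(OC)cc(OC)cc2OC)ccc1OC)c1ccc(F)cc1` differs from compound 3 as follows: (4-fluorophenyl)(methoxycarbonyl)methyl in place of hydrogen on a nitrogen on an aromatic ring (on a nitrogen on an aromatic ring).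

The measured steps bear on this only indirectly. Within the data shown here, both a 1700-fold lower number from compound 1 to compound 3 (3.22 log units; beyond the scatter) and a 2500-fold lower number from compound 2 to compound 3 (3.40 log units; beyond the scatter) are large, but they arise from changes on aromatic carbons, so the data hold no precedent for substitution on this nitrogen. Starting from the lowest number in the set, a weaker result is the likelier direction, with a moderate size and wide uncertainty. The expected step is a 13-fold higher number from compound 3 to compound 4 (1.12 log units; beyond the scatter) in this assay by this estimate. Compound 4 is expected at 40 nM (estimated range 5 nM to 800 nM).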

Compound 4, half-maximal inhibitory concentration: 2500 nM
Compound 4: middle estimate off by 63-fold (1.80 log units), on the low side, and the stated range ends below it.
By their numbers in this assay, from the lowest: compound 3; then compounds 4, 1 and 2 (each within the scatter of the next, the first and the last beyond it).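

In this assay the entry of (4-fluorophenyl)(methoxycarbonyl)methyl in place of hydrogen on the amino nitrogen gives an 830-fold higher number from compound 3 to compound 4 (2.92 log units; beyond the scatter) in a single change. Among these compounds, the earlier steps concerned aromatic carbons only, so this is the first sign that this nitrogen is also a place where one change produces a large step. No measurement at hand explains the step.

Open, as far as these compounds go, is whether a methyl or an acetyl on this nitrogen, or a carboxylic acid in place of the methyl ester, would stay close to compound 3.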